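This account rests on a few compounds, and the source may have more. Where it says the series, first, only, none or still open, it means among the compounds named here.

In an ADME assay on CCRF-HSB-2 cells (Homo sapiens) for cytotoxicity, with a stated time of 7 days (a higher number here means that more compound is tolerated, a lower number that less compound is tolerated), compound 1 `Nc1nc(NCc2ccccc2)c2ncn(/C=C3/CC3(CO)CO)c2n1` gives > 20000 nM, which is a limit of the assay. Compound 2 `Nc1nc(NC2CCCCC2)c2ncn(/C=C3/CC3(CO)CO)c2n1` gives > 20000 nM, also a limit. Going by the values given here, compound 3 `CCCCCCSc1nc(N)nc2c1ncn2/C=C1/CC1(CO)CO` gives 60000 nM, the only actual number among the three. Compound 4 `CCCCNc1nc(N)nc2c1ncn2/C=C1/CC1(CO)CO` has butylamino in place of hexylsulfanyl on an aromatic carbon. Among the compounds with values here, the steps that bear on this change are a step that the limit leaves unreadable from compound 1 to compound 3 and a step that the limit leaves unreadable from compound 2 to compound 3, and neither has a readable size. a step that the two limits leave unreadable from compound 1 to compound 2 adds no readable size either. The series offers only (the limit of > 20000 nM in this assay, at which 2 of the 3 values shown sit). In this assay, no change beyond the usual scatter is therefore expected, and the estimated step is a 1.2-fold lower number from compound 3 to compound 4 (0.08 log units; within the scatter). The estimate for compound 4 is 50000 nM, with an expected range of 15000 nM to 150000 nM.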

Compound 4, half-maximal cytotoxic concentration: > 20000 nM
Compound 4 ended at the assay's limit; the forecaster's own chance of this, stated with the estimate: 60%; the middle value does not contradict the limit.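

No new step can be read in this assay: every step reaching compound 4 from compound 1, compound 2 or compound 3 involves a limit of the assay. Going by these compounds, whether compound 1, compound 2 and compound 4 differ from compound 3, or from one another, stays open.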